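Fluoro in place of nitro: a step from a limit

The source may hold more compounds than are shown below. What is called first, only, known or untested is meant among the compounds shown, and "the series" means these compounds.

Of the compounds shown here, three sharing one core have been read so far in an ADME assay on HeLa cells (Homo sapiens) for cytotoxicity, read by crystal violet staining, with a stated time of 72 h; a higher number here means that more compound is tolerated, a lower number that less compound is tolerated. Compound 1 `CCOC(=O)c1cc(CCCOc2ccc(-c3noc(C(F)(F)F)n3)cc2C)on1`, which carries methyl, gives 35100 nM. Compound 2 `CCOC(=O)c1cc(CCCOc2ccc(-c3noc(C(F)(F)F)n3)cc2OC)on1`, which carries methoxy, gives > 100000 nM, and this is a limit of the assay and not a number. Compound 3 `CCOC(=O)c1cc(CCCOc2ccc(-c3noc(C(F)(F)F)n3)cc2[N+](=O)[O-])on1`, which carries nitro, gives > 100000 nM, again only a limit. From the compounds shown here alone, compound 3 therefore stands with compound 2 at the limit of > 100000 nM in this assay, at which 2 of the 3 values shown sit, and its exact place on the scale is unknown.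

Compound 4 `CCOC(=O)c1cc(CCCOc2ccc(-c3noc(C(F)(F)F)n3)cc2F)on1` changes one group of compound 3, with fluoro in place of nitro on an aromatic carbon. Going by the values given here, two measured steps concern that same carbon, an at least 2.8-fold higher number from compound 1 to compound 2 (0.45 log units; beyond the scatter) and an at least 2.8-fold higher number from compound 1 to compound 3 (0.45 log units; beyond the scatter). Both are known only as minimum sizes, while a step that the two limits leave unreadable from compound 2 to compound 3 offers nothing further. Among the compounds with values here, no measured step involves fluoro, so the expectation is loose. Compound 1 at 35100 nM shows that a small group on this carbon can bring the number inside the range of this assay, so a modest move towards a lower number is expected. The estimated step is an at least 1.6-fold lower number from compound 3 to compound 4 (0.22 log units; that floor lies within the scatter), and it may prove unreadable if another limit is reported. The estimate for compound 4 is 60000 nM, with an expected range of 25000 nM to 100000 nM.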

Compound 4, half-maximal cytotoxic concentration: 60200 nM
The estimate for compound 4 lay 1.0-fold (0.00 log units) below the measured number, and the stated range covers the measured number.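

In this assay, compound 4 is the second compound, after compound 1, whose number on this aromatic carbon falls inside the readable range, so this is not unique to methyl. Against methyl, the change gives a 1.7-fold higher number from compound 1 to compound 4 (0.23 log units; within the scatter), so fluoro and methyl cannot be told apart at this position, ortho to a large group. Against the two compounds known only by a limit, the change gives an at least 1.6-fold lower number from compound 3 to compound 4 (0.22 log units; that floor lies within the scatter) and an at least 1.6-fold lower number from compound 2 to compound 4 (0.22 log units; that floor lies within the scatter), minimum sizes that do not by themselves separate fluoro from nitro or methoxy, and those two compounds remain limits and not numbers: the limit of > 100000 nM in this assay, at which 2 of the 4 values shown sit.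

The compounds shown leave open how far beyond that limit the true numbers of compound 2 and compound 3 lie, so the methoxy and nitro compounds cannot be placed exactly against the fluoro compound. They also leave open what a chloro group, an amine or a carboxylic acid on this same carbon would give in this assay.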